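The source may report more compounds than this note shows. Statements on the series, on what has been measured and on what is new or still open speak of the compounds shown alone.

In an assay on CHO cells for positive allosteric modulation of metabotropic glutamate receptor 5 (Homo sapiens), read by FLIPR (on this read-out lower numbers stand for an effect already at smaller amounts and higher numbers for an effect only at larger amounts of compound), three compounds have been measured so far. Compound 1 `O=C(Nc1cccc(F)c1CN1C(=O)c2ccccc2C1=O)c1ccccn1` gives only a limit of the assay, > 100000 nM. Compound 2 `COc1ccccc1C(=O)Nc1ccc(Cl)cc1CN1C(=O)c2ccccc2C1=O` also gives only a limit of the assay, > 100000 nM, so it stands at the inactive end of what has been seen. Compound 3 `O=C(Nc1ccc(Cl)cc1CN1C(=O)c2ccc(F)cc2C1=O)c1ccccn1` gives a number, 330 nM. Two of the three results therefore sit at the limit of > 100000 nM in this assay, at which 2 of the 3 values shown sit. Compound 4 `O=C(Nc1ccc(Cl)cc1CN1C(=O)c2ccccc2C1=O)c1cncs1` has not yet been measured; it differs from compound 2 in one place: 1,3-thiazol-5-yl in place of 2-methoxyphenyl on a carbonyl carbon. The change from compound 2 to compound 4 is expected to bring a gain, roughly an at least 40-fold lower number from compound 2 to compound 4 (1.60 log units; beyond the scatter), toward an effect at smaller amounts. Compound 4 is therefore estimated at 2500 nM, with a likely range from 300 nM to 40000 nM.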

Compound 4, half-maximal effective concentration: 1900 nM
Compound 4: the middle estimate sits 1.3-fold (0.12 log units) above what was measured, and the stated range covers the measured number.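

The group on this carbonyl carbon strongly shapes the result: 1,3-thiazol-5-yl in place of 2-methoxyphenyl brings an at least 52-fold lower number from compound 2 to compound 4 (1.72 log units; beyond the scatter) in this assay and gives the first step readable between compounds differing in one place. Going by these compounds, the full size of this step stays unknown, as compound 2 gives only a limit: the limit of > 100000 nM in this assay, at which 2 of the 4 values shown sit.

On these data alone, whether the gain comes from losing 2-methoxyphenyl or from gaining 1,3-thiazol-5-yl remains open. Plain phenyl or a short chain such as ethyl on the same carbonyl carbon would help separate the two.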